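The source may hold more compounds than are shown below. What is called first, only, known or untested is meant among the compounds shown, and "the series" means these compounds.

Three compounds share one core and differ only in the aryl group on the aromatic nitrogen. In a functional assay on MCF7 cells (Homo sapiens) for antiproliferative activity, read by MTT assay, with a stated time of 72 h (on this read-out lower numbers stand for stronger inhibition of growth and higher numbers for weaker inhibition of growth), compound 1 `Cn1nc(-c2ccnc(Nc3ccc(O)cc3)n2)c2ccccc21` gives 8910 nM; compound 2 `Cn1nc(-c2ccnc(Nc3cccc(O)c3)n2)c2ccccc21` gives 28200 nM; compound 3 `Cn1nc(-c2ccnc(Nc3cccc(Cl)c3)n2)c2ccccc21` gives 5970 nM. Compound 1 stands second highest of the three numbers: a 3.2-fold higher number from compound 1 to compound 2 (0.50 log units; beyond the scatter), while a 1.5-fold lower number from compound 1 to compound 3 (0.17 log units; within the scatter). Between the other two, a 4.7-fold lower number from compound 2 to compound 3 (0.67 log units; beyond the scatter).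

Compound 4 `CCn1nc(-c2ccnc(Nc3ccc(O)cc3)n2)c2ccccc21` differs from compound 1 by methyl in place of hydrogen on a saturated chain carbon bound to an aromatic nitrogen; cut one bond further out, the same difference reads methyl to ethyl. None of the three measured steps touches this part of the molecule; all concern the aryl group on the aromatic nitrogen, so nothing in the series bears directly on the change from compound 1 to compound 4. Without a comparable step, the expectation is a number close to that of compound 1. Compound 4 is estimated at 8900 nM, with a range of 3500 nM to 22000 nM. The expected step is a 1.0-fold lower number from compound 1 to compound 4 (0.00 log units; within the scatter), that is, none beyond the scatter in either direction.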

Compound 4, concentration for 50% growth inhibition: 5780 nM
For compound 4 the middle estimate is 1.5-fold (0.19 log units) above the measured one; measured number inside the range.
By their numbers in this assay, from the lowest: compounds 4, 3 and 1 (each within the scatter of the next); then compound 2.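

In this assay the step is a 1.5-fold lower number from compound 1 to compound 4 (0.19 log units; within the scatter), so this first change on the saturated chain bound to an aromatic nitrogen, from methyl to ethyl, does not separate the two compounds. With the 4-hydroxyphenyl group held constant, this site therefore accepts one added methyl without a shift beyond the scatter, unlike the aryl change in a 3.2-fold higher number from compound 1 to compound 2 (0.50 log units; beyond the scatter). Nothing available here gives a reason for this result.

Still open, on these data alone, is whether the flat reading holds for a longer chain such as propyl, a branched chain such as isopropyl, or a chain ending in an amine or a carboxylic acid. Also open, as far as these compounds go, is whether ethyl behaves the same way when paired with the 3-chlorophenyl or 3-hydroxyphenyl group.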